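Amide chain extension in a melatonin receptor series

This account rests on a few compounds, and the source may have more. Where it says the series, first, only, none or still open, it means among the compounds named here.

Compound 1 `COc1ccc(CCCNC(C)=O)cc1` and compound 2 `CCC(=O)NCCCc1ccc(OC)cc1` share one core; compound 3 `CCCC(=O)NCCCc1cccc(Cl)c1` and compound 4 `CCCCC(=O)NCCCc1cccc(Cl)c1` share another, and the difference between the two cores is not broken down here. In an assay for binding affinity to melatonin receptor (Gallus gallus) (a lower number here means a stronger inhibitor, a higher number a weaker inhibitor), compound 1 gives 14000 nM, compound 2 gives 2900 nM and compound 3 gives 113 nM. The step of a 4.8-fold lower number from compound 1 to compound 2 (0.68 log units; beyond the scatter) is methyl in place of hydrogen on a saturated chain carbon bound to a carbonyl carbon. The change methyl in place of hydrogen on a saturated chain carbon, three bonds along the chain from a carbonyl carbon is the same kind of change, but its place is on a saturated chain carbon three bonds along the chain from a carbonyl carbon rather than bound to a carbonyl carbon, and the core is the other one. For compound 4 a smaller step of a 1.4-fold lower number from compound 3 to compound 4 (0.15 log units; within the scatter) is expected. Within the data shown here, that expectation rests on a 4.8-fold lower number from compound 1 to compound 2 (0.68 log units; beyond the scatter) alone, with no second example at the outer place. Compound 4 is estimated at 80 nM, between 30 nM and 300 nM.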

Compound 4, inhibition constant: 15100 nM
Compound 4: the middle estimate sits 190-fold (2.28 log units) below what was measured; the whole stated range lies below it.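

In this assay, methyl in place of hydrogen on a saturated chain carbon, three bonds along the chain from a carbonyl carbon, gives a 130-fold higher number from compound 3 to compound 4 (2.13 log units; beyond the scatter), so a gain seen on one core did not carry over as a gain on the other: the same change on two cores in this assay, a 4.8-fold lower number (0.68 log units; beyond the scatter) from compound 1 to compound 2 and a 130-fold higher number (2.13 log units; beyond the scatter) from compound 3 to compound 4, 650-fold (2.81 log units) apart, beyond the scatter of two such steps The two steps differ in place as well as in core, and these data cannot separate the two. With a single step on each core, they give no general rule for either core.

Open, from the compounds shown here alone, is how each place behaves on the other core, and whether an ethyl, a longer chain or an isopropyl group on the amide carbonyl of the core of compound 3 would restore the number seen for compound 3.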